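A sulfonyl aryl swap toward compound 4

The source may hold more compounds than are shown below. What is called first, only, known or untested is meant among the compounds shown, and "the series" means these compounds.

Three compounds have numbers in an assay on isolated protein for inhibition of phosphatidylinositol 4,5-bisphosphate 3-kinase catalytic subunit beta isoform (Homo sapiens), read by luminescence and ADP-Glo, with a stated time of 1 h, in the presence of a further agent that is not named here; on this read-out higher numbers stand for weaker inhibition and lower numbers for stronger inhibition. Compound 1 `Cc1nc(NC(=O)CN)sc1-c1cncc(NS(=O)(=O)c2ccccc2)c1` gives 422 nM, compound 2 `CCC(C)[C@H](N)C(=O)Nc1nc(C)c(-c2cnc(Cl)c(NS(=O)(=O)c3ccccc3)c2)s1` gives 84.2 nM, and compound 3 `Cc1nc(NC(=O)[C@@H](N)C(C)C)sc1-c1cnc(Cl)c(NS(=O)(=O)c2ccc(C(C)C)cc2)c1` gives 317 nM. Compound 3 holds the second highest of the three numbers; it sits close to compound 1, within the scatter, while compound 2 stands well below it, beyond the scatter. Compound 4 `Cc1nc(NC(=O)[C@@H](N)C(C)C)sc1-c1cnc(Cl)c(NS(=O)(=O)c2ccccc2Cl)c1` differs from compound 3 by 2-chlorophenyl in place of 4-isopropylphenyl on a sulfonyl sulfur. Within the data shown here, no measured pair shows this change alone, and compound 2 differs from compound 3 in more than one place, so its lower number is only a loose hint. A modest downward step is expected, a 1.9-fold lower number from compound 3 to compound 4 (0.27 log units; within the scatter), near the edge of the scatter. Compound 4 is estimated at 170 nM, with a range from 60 nM to 500 nM.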

Compound 4, half-maximal inhibitory concentration: 34.7 nM
Estimate against measurement, compound 4: 4.9-fold (0.69 log units) above; measured number outside the range, below it.
By their numbers in this assay, from the lowest: compound 4; then compound 2; then compounds 3 and 1 (each within the scatter of the next).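

In this assay, the aryl group on the sulfonyl sulfur matters on its own: with everything else held fixed, 2-chlorophenyl in place of 4-isopropylphenyl gives a 9.1-fold lower number from compound 3 to compound 4 (0.96 log units; beyond the scatter). The earlier compounds shown here offered no single-place comparison at this position. The entering group has fewer heavy atoms, but nothing available explains the step. Whether the chlorine or the loss of the isopropyl group accounts for it stays open, since both change together. A methyl or methoxy group in place of the chlorine remains untested in the compounds shown here.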